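Replacing the dichlorophenyl of compound 1 with fluorophenyl

The source may report more compounds than this note shows. Statements on the series, on what has been measured and on what is new or still open speak of the compounds shown alone.

Compound 1 `Cc1cc(N2CC[C@@H](C)[C@@H](N(C)c3ncnc4[nH]ccc34)C2)n2nc(SCc3cc(Cl)ccc3Cl)nc2n1`: 87500 nM
Compound 2 `COc1ccc(CSc2nc3nc(C)cc(N4CC[C@@H](C)[C@@H](N(C)c5ncnc6[nH]ccc56)C4)n3n2)cc1`: > 100000 nM

Among the measured compounds shown here, in a toxicity assay on GES1 cells (Homo sapiens) for inhibition, read by MTT assay, with a stated time of 72 h (a lower number here means a stronger inhibitor, a higher number a weaker inhibitor), compound 1 gives 87500 nM, the only real number among the two measured compounds. Compound 2 reaches only a limit of this assay, > 100000 nM. That limit is the limit of > 100000 nM in this assay, at which 1 of the 2 values shown sits. For the measured compounds named here, the one measured step, an at least 1.1-fold higher number from compound 1 to compound 2 (0.05 log units; that floor lies within the scatter), arises from swapping the same 2,5-dichlorophenyl on a saturated chain carbon bound to a sulfur, and its floor sits within the scatter, so it points weakly, if at all, toward a higher number.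

Compound 3 `Cc1cc(N2CC[C@@H](C)[C@@H](N(C)c3ncnc4[nH]ccc34)C2)n2nc(SCc3ccc(F)cc3)nc2n1` has not been measured in this assay. It differs from compound 1 by 4-fluorophenyl in place of 2,5-dichlorophenyl on a saturated chain carbon bound to a sulfur. Going by the values given here, only the step to compound 2 bears on this change, and it leaves open anything from no step beyond the scatter to a loss past the limit. Compound 3 is therefore expected to give about 120000 nM, with a range from 45000 nM to 320000 nM. The expected step is a 1.4-fold higher number from compound 1 to compound 3 (0.14 log units; within the scatter).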

Compound 3, half-maximal inhibitory concentration: 12300 nM
Compound 3: middle estimate off by 9.8-fold (0.99 log units), on the high side; the whole stated range lies above it.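

In this assay, the group on the saturated chain carbon bound to a sulfur can clearly shift the number, which the earlier step within the scatter did not show: 4-fluorophenyl in place of 2,5-dichlorophenyl gives a 7.1-fold lower number from compound 1 to compound 3 (0.85 log units; beyond the scatter). Fluoro in place of methoxy on an aromatic carbon gives an at least 8.1-fold lower number from compound 2 to compound 3 (0.91 log units; beyond the scatter), so compound 3 is the strongest inhibitor of the three, and the result depends on which group the phenyl ring carries, not merely on the presence of that ring. The value of compound 2, > 100000 nM, is a limit of this assay.

The compounds shown leave open whether the lower number follows from gaining the fluorine or from losing the two chlorines, as the step from compound 1 changes both at once. An unsubstituted phenyl or a 4-chlorophenyl on the same carbon would help to separate the two.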